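Chloro for fluoro on a bis-benzylidene diketopiperazine scaffold

The source may report more compounds than this note shows. Statements on the series, on what has been measured and on what is new or still open speak of the compounds shown alone.

The series was tested in a functional assay on Huh-7 cells (Homo sapiens) for cytotoxicity, read by CCK-8 assay, with a stated time of 72 h; on this read-out lower numbers stand for stronger inhibition and higher numbers for weaker inhibition. Compound 1 `COc1ccccc1/C=c1/[nH]c(=O)/c(=C\c2ccccc2OC)[nH]c1=O` gave "not active" (no number reported), with no number reported. Compound 2 `C=CCn1c(=O)/c(=C\c2ccc(Cl)c(Cl)c2)[nH]c(=O)/c1=C\c1ccccc1` likewise gave "not active" (no number reported) without a number. Going by the values given here, compound 3 `C=CCn1c(=O)/c(=C\c2cccc(F)c2)[nH]c(=O)/c1=C\c1ccccc1OC` is the only member with a measured value, giving 27200 nM in this assay, so it stands as the sole numerical anchor of the set. Compound 4 `C=CCn1c(=O)/c(=C\c2cccc(Cl)c2)[nH]c(=O)/c1=C\c1ccccc1OC` differs from compound 3 by chloro in place of fluoro on an aromatic carbon. Among the compounds with values here, no pair of measured compounds shares this change, so nothing in the data tells its direction. Compound 4 is therefore expected to land within the scatter of compound 3, with a step of a 1.2-fold lower number from compound 3 to compound 4 (0.09 log units; within the scatter). Compound 4 is expected to show 22000 nM, in the range from 8000 nM to 60000 nM.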

Compound 4, half-maximal inhibitory concentration: 8900 nM
Beside the measured number, compound 4's estimate is 2.5-fold (0.39 log units) above it, and the stated range covers the measured number.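

Chloro in place of fluoro gives a 3.1-fold lower number from compound 3 to compound 4 (0.49 log units; beyond the scatter) in this assay and so supplies the first measured change in this set. It shows that the number responds to the halogen on this aromatic carbon, meta to a large group, although the step is modest and rests on this single pair. Nothing shown accounts for the change. The compounds shown leave open how bromo, an amine or a carboxylic acid on this carbon would read, and whether the same step would recur with the 3-chlorophenyl group on a differently substituted core.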